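This account rests on a few compounds, and the source may have more. Where it says the series, first, only, none or still open, it means among the compounds named here.

Measured so far:
Compound 1, `c1ccc(COc2cccc(-c3cn([C@@H]4CN5CCC4CC5)nn3)c2)cc1`: 414 nM
Compound 2, `c1ccc(COc2cccc(-c3cn(C4CN5CCC4CC5)nn3)c2)cc1`: 668 nM

In an assay on HEK293 cells for displacement of a labelled ligand from Neuronal acetylcholine receptor; alpha4/beta2 (Homo sapiens), read by scintillation counting, with a stated time of 120 min (a lower number here means a stronger inhibitor, a higher number a weaker inhibitor), compound 1 gives 414 nM, the lowest of the two numbers, and compound 2 gives 668 nM. Among the compounds with values here, the one measured step, a 1.6-fold higher number from compound 1 to compound 2 (0.21 log units; within the scatter), rests only on (the fact that one of compounds 1 and 2 is drawn with a defined configuration and the other without, at the place where they differ). Compound 3, `FCCOc1cccc(-c2cn([C@@H]3CN4CCC3CC4)nn2)c1`, carries a different change: fluoromethyl in place of phenyl on a saturated chain carbon bound to an oxygen on an aromatic ring. Within the data shown here, no measured step touches this part of the molecule, so the size of the step in this assay cannot be read from what is known; a modest shift in either direction is plausible. Compound 3 is expected to give 600 nM, with a range from 150 nM to 2500 nM. That expectation corresponds to an estimated step of a 1.4-fold higher number from compound 1 to compound 3 (0.16 log units; within the scatter).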

Compound 3, inhibition constant: 1260 nM
Compound 3: the middle estimate sits 2.1-fold (0.32 log units) below what was measured; the measured number falls inside the stated range.
By their numbers in this assay, from the lowest: compounds 1, 2 and 3 (each within the scatter of the next, the first and the last beyond it).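

In this assay, replacing phenyl with fluoromethyl on a saturated chain carbon bound to an oxygen on an aromatic ring gives a 3.0-fold higher number from compound 1 to compound 3 (0.48 log units; beyond the scatter). Within the data shown here, this is the first measured change at this position, and it shows that the group there can move the number beyond the scatter, which the earlier pair, differing only in a drawn stereocentre, could not show. Nothing given here explains this step.

The compounds shown leave open whether the step comes from losing the phenyl ring or from gaining the fluorine. A plain ethyl or a fluorobenzyl group at this position would separate the two.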